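Adding one fluoro to the benzamide of compound 2

The source may hold more compounds than are shown below. What is called first, only, known or untested is meant among the compounds shown, and "the series" means these compounds.

Values in a functional assay on SMMC-7721 cells (Homo sapiens) for inhibition, read by CCK-8 assay, with a stated time of 72 h; on this read-out higher numbers stand for weaker inhibition and lower numbers for stronger inhibition:
compound 1 `Nc1ccccc1NC(=O)c1ccc(CNC(=O)c2n[nH]cc2NC(=O)c2c(F)cccc2Cl)cc1` gives 16300 nM
compound 2 `Nc1ccccc1NC(=O)c1ccc(CNC(=O)c2n[nH]cc2NC(=O)c2ccccc2)cc1` gives 6620 nM
compound 3 `O=C(NO)c1ccc(CNC(=O)c2n[nH]cc2NC(=O)c2c(Cl)cccc2Cl)cc1` gives 14600 nM

Compound 2, at 6620 nM, holds the lowest of the three numbers in this assay, and its gaps to the other two lie beyond the usual scatter. The next compound is compound 4 `Nc1ccccc1NC(=O)c1ccc(CNC(=O)c2n[nH]cc2NC(=O)c2ccccc2F)cc1`, which turns the phenyl of compound 2 into 2-fluorophenyl. The change is fluoro in place of hydrogen on an aromatic carbon, ortho to a large group.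

Among the compounds with values here, one measured step bears on this: a 2.5-fold lower number from compound 1 to compound 2 (0.39 log units; beyond the scatter), a modest change with phenyl in place of 2-chloro-6-fluorophenyl on a carbonyl carbon. Compound 4 carries part of that substitution, so the same direction, read backwards, suggests a somewhat higher number than compound 2 shows. The data do not separate the share of the fluoro from that of the chloro. Within the data shown here, compound 3, at 14600 nM, differs from compound 2 in more than one place and gives no step for this change.

The expected change is smaller than the measured one, an estimated 1.4-fold higher number from compound 2 to compound 4 (0.13 log units; within the scatter), and it may not clear the scatter. Compound 4 is estimated at 9000 nM, with an expected range of 4000 nM to 18000 nM.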

Compound 4, half-maximal inhibitory concentration: 6850 nM
Compound 4: the middle estimate sits 1.3-fold (0.12 log units) above what was measured; the measured number falls inside the stated range.
By their numbers in this assay, from the lowest: compounds 2 and 4 (each within the scatter of the next); then compounds 3 and 1 (each within the scatter of the next).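

In this assay, fluoro in place of hydrogen on the benzamide ring, ortho to a large group, is tolerated here, with a 1.0-fold higher number from compound 2 to compound 4 (0.01 log units; within the scatter) lying within the scatter, so this single fluoro accounts for no measurable part of the earlier step between the phenyl and the 2-chloro-6-fluorophenyl compounds. Removing the chloro while keeping the fluoro gives a 2.4-fold lower number from compound 1 to compound 4 (0.38 log units; beyond the scatter), which lies beyond the scatter and is close in size to a 2.5-fold lower number from compound 1 to compound 2 (0.39 log units; beyond the scatter), so within this set the difference between those two compounds follows the chloro and not the fluoro. Nothing available measures why the chloro changes the number in this assay while the fluoro does not.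

Going by these compounds, the chloro step was read only on a ring that also carries fluoro, so it remains open whether a 2-chlorophenyl without fluoro would give a number like that of compound 1 or like that of compound 4. On these data alone, it is also open whether a methoxy, a methyl or an amine at the same place on this ring would stay as close to compound 2 as the fluoro does, or shift the number as the chloro does.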